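Chlorine replaces three fluorines at the assay limit

This account rests on a few compounds, and the source may have more. Where it says the series, first, only, none or still open, it means among the compounds named here.

Three compounds share one core and differ only in the ring on the nitrogen: compound 1 (`C=C[C@@](C)(/C=C/c1ccc(Nc2ccc(F)cc2)cc1)CCC=C(C)C`), compound 2 (`C=C[C@@](C)(/C=C/c1ccc(Nc2cc(F)c(F)c(F)c2)cc1)CCC=C(C)C`) and compound 3 (`C=C[C@@](C)(/C=C/c1ccc(Nc2c(F)cc(F)cc2F)cc1)CCC=C(C)C`). In a functional assay on Raji cells (Homo sapiens) for cytotoxicity, with a stated time of 72 h (a lower number here means that less compound is needed, a higher number that more compound is needed for the effect), compound 1 gives > 26000 nM, which is a limit and not a number. Compound 2 gives > 26000 nM, again a limit. Compound 3 gives > 26000 nM, also a limit. So compound 3 has no exact position, and the whole set shares one reading: the limit of > 26000 nM in this assay, at which 3 of the 3 values shown sit.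

The next compound, compound 4 (`C=C[C@@](C)(/C=C/c1ccc(Nc2ccc(Cl)cc2)cc1)CCC=C(C)C`), brings one change: 4-chlorophenyl in place of 2,4,6-trifluorophenyl on a nitrogen on an aromatic ring. Put simply, 4-chlorophenyl stands in place of 2,4,6-trifluorophenyl on a nitrogen on an aromatic ring.

Within the data shown here, three measured steps bear on this swap, since each also exchanges the ring on the nitrogen: a step that the two limits leave unreadable from compound 1 to compound 2, a step that the two limits leave unreadable from compound 1 to compound 3 and a step that the two limits leave unreadable from compound 2 to compound 3. None has a size that can be read, so they offer no direction to carry over. No step beyond the scatter is therefore expected in this assay, and the expected change is a number no higher from compound 3 to compound 4 (the limit leaves the size open). Compound 4 is estimated at 26000 nM, with an expected range of 12000 nM to 50000 nM, and the assay may well report only a limit again.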

Compound 4, half-maximal effective concentration: > 26000 nM
Compound 4: a limit, no number; the forecaster's own chance of this, stated with the estimate: 80%; the middle value lies on the limit itself.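

In this assay compound 4 gives > 26000 nM, which is a limit and not a number. Its steps from compound 1, compound 2 and compound 3 therefore cannot be read. The compounds shown leave open how far the ring on the nitrogen changes the result, as all of them share one reading: the limit of > 26000 nM in this assay, at which 4 of the 4 values shown sit.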